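Phenyl Amide Variant of a Thiazolidinedione-Naphthyl Series

The compounds below may be only part of what the source reports. "The series", "measured", "known", "first", "only" and "open" are said of these compounds alone.

The series shares a core carrying an aryl amide, and the account turns on that aryl group. Compound 1 `O=C(COc1ccc2cc(/C=C3/SC(=O)NC3=O)ccc2c1)Nc1c(F)cc(F)cc1Br` is tested in an assay on isolated protein for inhibition of histone deacetylase 8 (Homo sapiens), with a stated time of 1 h; on this read-out higher numbers stand for weaker inhibition and lower numbers for stronger inhibition; compound 1 gives > 50000 nM, which is a limit of the assay and not a number. Compound 3 `O=C(COc1ccc2cc(/C=C3/SC(=O)NC3=O)ccc2c1)Nc1ccc(Br)c(Br)c1` likewise gives > 50000 nM in this assay, also a limit. Compound 2 `CCOc1ccc2nc(NC(=O)COc3ccc4cc(/C=C5/SC(=O)NC5=O)ccc4c3)sc2c1` gives 17000 nM in this assay. Compound 1 therefore stands at the limit of > 50000 nM in this assay, at which 2 of the 3 values shown sit. Among the compounds with values here, the one change with both ends measured, a step that the two limits leave unreadable from compound 1 to compound 3, leaves its size unreadable, so nothing measured tells how a swap of the amide aryl moves the numbers. Compound 4 `O=C(COc1ccc2cc(/C=C3/SC(=O)NC3=O)ccc2c1)Nc1ccccc1` has not been measured; it differs from compound 1 by phenyl in place of 2-bromo-4,6-difluorophenyl on an amide-type nitrogen. Compound 4 is expected to remain weak, with an estimated step of an at least 1.2-fold lower number from compound 1 to compound 4 (0.09 log units; that floor lies within the scatter) and an expected value of 40000 nM between 10000 nM and 100000 nM, and it may again return only a limit.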

Compound 4, half-maximal inhibitory concentration: 4500 nM
The estimate for compound 4 lay 8.9-fold (0.95 log units) above the measured number; measured number below the stated range.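

Swapping the aryl group on the amide-type nitrogen does move the number in this assay, which compound 1 and compound 3, whose step cannot be read, did not show. Phenyl in place of 2-bromo-4,6-difluorophenyl brings an at least 11-fold lower number from compound 1 to compound 4 (1.04 log units; beyond the scatter), and phenyl in place of 3,4-dibromophenyl brings an at least 11-fold lower number from compound 3 to compound 4 (1.04 log units; beyond the scatter). Each step is only a floor, because its starting compound sits at a limit of the assay: the limit of > 50000 nM in this assay, at which 2 of the 4 values shown sit.

The compounds shown leave open how large the two steps really are, and whether a single bromine on the phenyl would already return the number to the limit. They also leave open how a phenyl bearing a methoxy group, an amine or a carboxylic acid would read.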